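This account rests on a few compounds, and the source may have more. Where it says the series, first, only, none or still open, it means among the compounds named here.

Measured in an ADME assay on HEK293 cells (Homo sapiens) for cytotoxicity, read by CellTiter-Glo and resazurin assay, with a stated time of 72 h; on this read-out higher numbers stand for an effect only at larger amounts of compound and lower numbers for an effect already at smaller amounts:
Compound 1 `CC(C)Oc1cccc(-c2ccc(C(=O)N(Cc3cccc(OCCCCCC(=O)O)c3)C(C)C)cc2)c1`: > 26000 nM
Compound 2 `CC(C)N(Cc1cccc(OCCCCCC(=O)O)c1)C(=O)c1ccc(-c2ccc3c(c2)OCCO3)cc1`: > 21900 nM
Compound 3 `COc1ccc(F)c(-c2ccc(C(=O)N(Cc3cccc(OCCCCCC(=O)O)c3)C(C)C)cc2)c1`: > 26000 nM

Each of these entries is a limit and not a number. Compound 3 has only its limit of > 26000 nM, so it cannot be ranked against the other two compounds. The three entries fall at two limits: the limit of > 26000 nM in this assay, at which 2 of the 3 values shown sit, and (the limit of > 21900 nM in this assay, at which 1 of the 3 values shown sits).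

Compound 4 `CC(C)N(Cc1cccc(OCCCCCC(=O)O)c1)C(=O)c1ccc(-c2cccc(Cl)c2)cc1` differs from compound 3 at a single place: 3-chlorophenyl in place of 2-fluoro-5-methoxyphenyl on an aromatic carbon. In words, it carries 3-chlorophenyl in place of 2-fluoro-5-methoxyphenyl on an aromatic carbon.

Three measured steps exchange the group at this same place: a step that the two limits leave unreadable from compound 1 to compound 2, a step that the two limits leave unreadable from compound 1 to compound 3 and a step that the two limits leave unreadable from compound 2 to compound 3. None of them has a readable size, and none gives a direction. Among the measured compounds shown here, no compound with a measured number is available as a guide, so no step beyond the usual scatter is expected in this assay.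

The expectation starts from the limit of compound 3, > 26000 nM. The estimated step is a number no higher from compound 3 to compound 4 (the limit leaves the size open), with no direction favoured. For compound 4 the expected value is 26000 nM, with an estimated range from 14000 nM to 50000 nM. A report as a limit is again the likeliest outcome.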

Compound 4, half-maximal effective concentration: > 21900 nM
Compound 4 was reported as a limit (the forecaster's own chance of this, stated with the estimate: 85%); the middle value is on the limit's open side.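

In this assay compound 4 gives > 21900 nM, which is a limit and not a number. Among the compounds shown here, no step to compound 4 from compound 1, compound 2 or compound 3 can be read, as all four entries are limits. The compounds shown leave open where any of them would reach its half-maximal effect in this assay, and whether exchanging the group at this place changes it.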